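The source may report more compounds than this note shows. Statements on the series, on what has been measured and on what is new or still open speak of the compounds shown alone.

Compound 1 `C=C(Br)C(=O)Nc1cccc(-c2cn3nc(-c4ccc(OCC)cc4)sc3n2)c1` in a functional assay on L1210 cells (Mus musculus) for inhibition, read by cell counting, with a stated time of 2 days (on this read-out higher numbers stand for weaker inhibition and lower numbers for stronger inhibition), gives 790 nM.
Compound 3 `C=C(Br)C(=O)Nc1cccc(-c2cn3nc(-c4ccc(Cl)cc4)sc3n2)c1` in this assay gives 1400 nM.
Compound 2 `COc1cccc(-c2nn3cc(-c4cccc(N)c4)nc3s2)c1` in this assay reaches only a limit of the assay, > 250000 nM.

Among the two numbers shown, compound 3 has the highest, with compound 1 the nearest at a 1.8-fold higher number from compound 1 to compound 3 (0.25 log units; within the scatter), a gap that stays within the scatter, so the two are not told apart here. Within the data shown here, the value for compound 2 is a limit and not a number (the limit of > 250000 nM in this assay, at which 1 of the 3 values shown sits); it shows that without the bromoacrylamide the cells are left unaffected, yet compound 2 differs from every other compound in more than one place, so no single step can be drawn from it.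

Compound 4 `C=C(Br)C(=O)Nc1cccc(-c2cn3nc(-c4cccc(OC)c4)sc3n2)c1` is reached from compound 3 by 3-methoxyphenyl in place of 4-chlorophenyl on an aromatic carbon. Among the measured compounds shown here, the only measured step at this position, a 1.8-fold higher number from compound 1 to compound 3 (0.25 log units; within the scatter), exchanged one group for another on the same ring and stayed within the scatter. Since the bromoacrylamide is kept and only the aromatic group at the far end is exchanged, the expected step of a 1.1-fold lower number from compound 3 to compound 4 (0.03 log units; within the scatter) is none beyond the scatter. Compound 4 is therefore estimated at 1300 nM, with a range from 450 nM to 4000 nM.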

Compound 4, half-maximal inhibitory concentration: 580 nM
Beside the measured number, compound 4's estimate is 2.2-fold (0.35 log units) above it; measured number inside the range.
By their numbers in this assay, from the lowest: compounds 4, 1 and 3 (each within the scatter of the next, the first and the last beyond it). At a limit, above all of these: compound 2.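

a 2.4-fold lower number from compound 3 to compound 4 (0.38 log units; beyond the scatter) is the first step at this position to pass beyond the scatter, though only modestly, while the exchange of 4-ethoxyphenyl for 3-methoxyphenyl, a 1.4-fold lower number from compound 1 to compound 4 (0.13 log units; within the scatter), stays within it. The bromoacrylamide can now be read as a single change, with (1-bromoethenyl)carbonyl in place of hydrogen on the nitrogen: an at least 430-fold lower number from compound 2 to compound 4 (2.63 log units; beyond the scatter). That step is large, but its size rests on compound 2, whose value is a limit and not a number: the limit of > 250000 nM in this assay, at which 1 of the 4 values shown sits.

Going from 4-chlorophenyl to 3-methoxyphenyl changes both the group and where it sits on the phenyl ring, so the compounds shown do not separate these two effects. On these data alone, how an amine or a carboxylic acid on that phenyl ring would fare also remains open.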